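The source may report more compounds than this note shows. Statements on the series, on what has been measured and on what is new or still open speak of the compounds shown alone.

Of the compounds shown here, three sharing one core have been measured in a functional assay on the whole organism with Mus musculus as the target; a lower number here means that less compound is needed, a higher number that more compound is needed for the effect. In this test, compound 1 `CN(C)C(=O)/C=C1\CCc2c(F)cc(F)cc21` gives 50 mg/kg, compound 2 `CNC(=O)/C=C1\CCc2c(F)cc(F)cc21` gives 45 mg/kg, and compound 3 `O=C(/C=C1\CCc2c(F)cc(F)cc21)NC1CC1` gives 62 mg/kg. Compound 3 therefore stands level with the other two, as all three values lie within the normal scatter of one another.

The still unmeasured compound 4 `O=C(/C=C1\CCc2c(F)cc(F)cc21)NCCO` carries 2-hydroxyethyl in place of cyclopropyl on an amide-type nitrogen. Three measured changes bear on this: a 1.1-fold lower number from compound 1 to compound 2 (0.05 log units; within the scatter), a 1.2-fold higher number from compound 1 to compound 3 (0.09 log units; within the scatter) and a 1.4-fold higher number from compound 2 to compound 3 (0.14 log units; within the scatter). All of them stayed within the scatter. Among the measured compounds shown here, none of the measured compounds carries a 2-hydroxyethyl group, however, so the range must stay wide. Going by a 1.4-fold higher number from compound 2 to compound 3 (0.14 log units; within the scatter), the closest swap on this nitrogen, no step beyond the scatter is expected in this assay. The estimated change is a 1.0-fold lower number from compound 3 to compound 4 (0.01 log units; within the scatter). For compound 4 the expected value is 60 mg/kg, with an estimated range of 30 mg/kg to 130 mg/kg.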

Compound 4, dose for half-maximal effect: 100 mg/kg
Beside the measured number, compound 4's estimate is 1.7-fold (0.22 log units) below it, and the stated range covers the measured number.
By their numbers in this assay, from the lowest: compounds 2, 1, 3 and 4 (each within the scatter of the next, the first and the last beyond it).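

In this assay, among the compounds shown here, the changes on this amide-type nitrogen had so far stayed within the scatter, and 2-hydroxyethyl gives the first step beyond it, though only a modest one: a 2.2-fold higher number from compound 2 to compound 4 (0.35 log units; beyond the scatter). This holds only against the methylamide, since the other two steps remain within the scatter: a 1.6-fold higher number from compound 3 to compound 4 (0.21 log units; within the scatter) and a 2.0-fold higher number from compound 1 to compound 4 (0.30 log units; within the scatter). So this nitrogen accepts a chain ending in a hydroxyl group with little change in the dose needed, and no measurement here explains the one step that does exceed the scatter.

Going by these compounds, it remains open how a plain ethyl group, which has the chain without the hydroxyl, would compare with 2-hydroxyethyl on this nitrogen. The same goes for a 2-methoxyethyl group, a 2-aminoethyl group or a longer chain such as 3-hydroxypropyl.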